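This account rests on a few compounds, and the source may have more. Where it says the series, first, only, none or still open, it means among the compounds named here.

Three compounds built on one shared core are compared here, differing only in the group carried on an amine nitrogen in a ring. Compound 1, `CCCn1c(=O)[nH]c2nc(-c3ccc(S(=O)(=O)N4CCN(c5ccccc5F)CC4)cc3)[nH]c2c1=O`, is tested in an assay on CHO cells for displacement of a labelled ligand from adenosine receptor A3 (Homo sapiens), read by scintillation counting, with a stated time of 45 min, tested at 1 uM, in the presence of a further agent that is not named here (on this read-out lower numbers stand for less inhibition and higher numbers for more inhibition at the one concentration tested (going by the name of the read-out)), and gives 9%. Compound 2, `CCCn1c(=O)c2[nH]c(-c3ccc(S(=O)(=O)N4CCN(c5ccc(Cl)cc5)CC4)cc3)nc2n(C)c1=O`, gives 39% in this assay, while compound 3, `CCCn1c(=O)[nH]c2nc(-c3ccc(S(=O)(=O)N4CCN(c5ccccc5)C(C)C4)cc3)[nH]c2c1=O`, gives -2%. Among these three numbers compound 1 stands second highest: compound 3 lies lower by a margin beyond the usual scatter, and compound 2 lies higher, also beyond the scatter.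

Compound 4, `CCCn1c(=O)[nH]c2nc(-c3ccc(S(=O)(=O)N4CCN(Cc5ccc(Br)cc5)CC4)cc3)[nH]c2c1=O`, has not been measured yet. Compared with compound 1 it differs in one place: 4-bromobenzyl in place of 2-fluorophenyl on an amine nitrogen in a ring. Within the data shown here, no measured pair shows this particular change, so its effect is unknown from the data. The expected step from compound 1 to compound 4 in this assay is a number 3 percentage points higher from compound 1 to compound 4 (within the scatter), a change that is expected to stay within the scatter, because compound 1 itself gives 9% and nothing measured points to a different direction. Compound 4 is therefore estimated at 12%, with a range from -10% to 35%.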

Compound 4, a percentage reported as inhibition, at one concentration (the size of the read-out at that concentration, not a potency): 28%
Compound 4: the middle estimate sits 16 percentage points below what was measured, within the range that was stated.
By their numbers in this assay, from the lowest: compound 3; then compound 1; then compound 4; then compound 2.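

Among these compounds, on an amine nitrogen in a ring, putting 4-bromobenzyl in place of 2-fluorophenyl gives a number 19 percentage points higher from compound 1 to compound 4 (beyond the scatter) in this assay, the first single-place step in this set, and it shows that the group on this nitrogen can shift the read-out. The two groups match in carrying one six-membered aromatic ring of carbon only and no hydrogen-bond donors or acceptors, so the step comes with a change of halogen, of its place on the aromatic ring and of how that ring is attached to the nitrogen. Nothing available explains the rise.

This one step cannot show which of those differences matters. A plain benzyl group on the same nitrogen would separate the halogen from the attachment, and a longer chain such as phenylethyl would test the distance from the aromatic ring.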